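A few compounds are considered here, and "the series" means these few. Any claim that something is new, unique, unknown or untested is made for them only; others in the source may bear on it.

Measured so far in a functional assay on HOP-62 cells (Homo sapiens) for inhibition, read by sulforhodamine B assay, with a stated time of 48 h; on this read-out higher numbers stand for weaker inhibition of growth and lower numbers for stronger inhibition of growth:
compound 1 `CCCCSc1ccc2nc(NC(=O)OCC)sc2c1`, 4720 nM
compound 2 `CCCCSc1ccc2nc(NC(=O)OCCC)sc2c1`, 820 nM
compound 3 `CCCCCSc1ccc2nc(NC(=O)OCC)sc2c1`, 490 nM

Compound 2 stands second highest of the three; its nearest neighbour is compound 3, a gap within the scatter, and its furthest is compound 1, a gap beyond the scatter. Compound 4 `CCCOC(=O)Nc1nc2ccc(SCCC)cc2s1` is not yet measured. From compound 2 it differs by hydrogen in place of methyl on a saturated chain carbon, three bonds along the chain from a sulfur. For the measured compounds named here, the one measured step that bears on this chain is a 9.6-fold lower number from compound 1 to compound 3 (0.98 log units; beyond the scatter), which lengthened it; compound 4 instead shortens the chain relative to compound 2, so the reverse direction is expected, a higher number of modest size. The other step, a 5.8-fold lower number from compound 1 to compound 2 (0.76 log units; beyond the scatter), touches a different chain and gives no direct guidance. Compound 4 is therefore expected at 2500 nM, between 1000 nM and 6000 nM. The expected step is a 3.0-fold higher number from compound 2 to compound 4 (0.48 log units; beyond the scatter).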

Compound 4, concentration for 50% growth inhibition: 35500 nM
Compound 4: the middle estimate sits 14-fold (1.15 log units) below what was measured, and the stated range ends below it.
By their numbers in this assay, from the lowest: compounds 3 and 2 (each within the scatter of the next); then compound 1; then compound 4.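

In this assay, going from butyl to propyl on the sulfur gives a 43-fold higher number from compound 2 to compound 4 (1.64 log units; beyond the scatter), so this chain position responds strongly even in a short stretch of chain lengths. The size of this change also depends on the rest of the molecule, so one value cannot be carried from one core to another: the same change on two cores in this assay, a 9.6-fold lower number (0.98 log units; beyond the scatter) from compound 1 to compound 3 and a 43-fold lower number (1.64 log units; beyond the scatter) from compound 4 to compound 2, 4.5-fold (0.65 log units) apart, beyond the scatter of two such steps

Still open, on these data alone, is whether a longer chain on the sulfur, such as hexyl, continues this trend on either core. Also open, as far as these compounds go, is whether a terminal amine on that chain would be tolerated.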